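The source may hold more compounds than are shown below. What is called first, only, known or untested is meant among the compounds shown, and "the series" means these compounds.

In a functional assay on A549 cells (Homo sapiens) for cytotoxicity, read by MTT assay (on this read-out lower numbers stand for stronger inhibition and higher numbers for weaker inhibition), compound 1 `CCn1cc(C(=O)Nc2ccc(Cl)cn2)c(=O)c2cc(F)c(N3CCNC(C)C3)c(F)c21` gives 3300 nM and compound 2 `CCn1cc(C(=O)Nc2cccc([N+](=O)[O-])c2)c(=O)c2cc(F)c(N3CCNC(C)C3)c(F)c21` gives 3240 nM while compound 3 `CCn1cc(C(=O)Nc2ccc(C(C)=O)cc2)c(=O)c2cc(F)c(N3CCNC(C)C3)c(F)c21` reads 4000 nM without standing apart. Compound 3 thus sits within the scatter of both others. Compound 4 `CCn1cc(C(=O)Nc2ccc(OC(F)(F)F)cc2)c(=O)c2cc(F)c(N3CCNC(C)C3)c(F)c21` has trifluoromethoxy in place of acetyl on an aromatic carbon and otherwise matches compound 3. The nearest evidence comes from swaps of the whole aryl group on the amide-type nitrogen: a 1.2-fold higher number from compound 1 to compound 3 (0.08 log units; within the scatter) and a 1.2-fold higher number from compound 2 to compound 3 (0.09 log units; within the scatter) and also a 1.0-fold lower number from compound 1 to compound 2 (0.01 log units; within the scatter) all lie within the scatter. So no step beyond the scatter is expected in this assay here, and a 1.1-fold lower number from compound 3 to compound 4 (0.06 log units; within the scatter) is the estimated step. The estimate for compound 4 is 3500 nM with an expected range from 1800 nM to 6500 nM for now.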

Compound 4, half-maximal inhibitory concentration: 1320 nM
For compound 4 the middle estimate is 2.7-fold (0.42 log units) above the measured one; measured number below the stated range.
By their numbers in this assay, from the lowest: compound 4; then compounds 2, 1 and 3 (each within the scatter of the next).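

In this assay the aryl group on the amide-type nitrogen now shows that it can shift the number, since the earlier aryl swaps all stayed within the scatter. Here 4-(trifluoromethoxy)phenyl goes beyond it, with a 3.0-fold lower number from compound 3 to compound 4 (0.48 log units; beyond the scatter) and a 2.5-fold lower number from compound 2 to compound 4 (0.39 log units; beyond the scatter) and also a 2.5-fold lower number from compound 1 to compound 4 (0.40 log units; beyond the scatter) as modest steps, all resting on this one compound. Nothing shown explains why this group stands apart. Still open, going by these compounds, is whether a methoxy group or an amine on the same aromatic carbon would give a similar step.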